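A few compounds are considered here, and "the series" means these few. Any claim that something is new, unique, unknown or untested is made for them only; others in the source may bear on it.

Working notes on the series. Compound 3 `CCN(CC)Cc1cc(-c2ccc(F)cc2)n(Nc2ccnc3cc(Cl)ccc23)c1C` has been run in an ADME assay on WEHI13 cells (Mus musculus) for cytotoxicity, read by MTT assay, with a stated time of 72 h (a lower number here means that less compound is tolerated, a higher number that more compound is tolerated), where compound 3 gives 3020 nM. For comparison, compound 1 `Cc1c(CN2CCCC2)cc(-c2ccccc2)n1Nc1ccnc2cc(Cl)ccc12` gives 3880 nM in this assay, and compound 2 `Cc1c(CN2CCCC2)cc(-c2ccc(Cl)cc2)n1Nc1ccnc2cc(Cl)ccc12` gives 2060 nM. The number for compound 3 sits among these two without separating from either beyond the scatter, compound 1 being the nearer and compound 2 the further. Within the data shown here, the only single-point step among the measured compounds is a 1.9-fold lower number from compound 1 to compound 2 (0.27 log units; within the scatter), and it concerns a different part of the molecule from the change now at hand.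

Compound 4 `Cc1c(CN2CCCC2)cc(-c2ccc(F)cc2)n1Nc1ccnc2cc(Cl)ccc12` differs from compound 3 by pyrrolidin-1-yl in place of diethylamino on a saturated chain carbon bound to an aromatic carbon. Among the measured compounds shown here, no measured pair isolates this exchange, so nothing supports a step beyond the scatter in this assay, in either direction. For compound 4 the step of a 1.0-fold lower number from compound 3 to compound 4 (0.00 log units; within the scatter) is expected to stay within the scatter. Compound 4 is accordingly estimated at 3000 nM, with a range from 1500 nM to 6000 nM.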

Compound 4, half-maximal cytotoxic concentration: 2710 nM
Estimate against measurement, compound 4: 1.1-fold (0.04 log units) above; measured number inside the range.
By their numbers in this assay, from the lowest: compounds 2, 4, 3 and 1 (each within the scatter of the next).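

In this assay the exchange of diethylamino for pyrrolidin-1-yl on a saturated chain carbon bound to an aromatic carbon can now be read directly, as a 1.1-fold lower number from compound 3 to compound 4 (0.05 log units; within the scatter). With pyrrolidin-1-yl held constant, the substituent on an aromatic carbon gives a 1.3-fold higher number from compound 2 to compound 4 (0.12 log units; within the scatter) for fluoro in place of chloro and a 1.4-fold lower number from compound 1 to compound 4 (0.16 log units; within the scatter) for fluoro in place of hydrogen, so neither halogen exchange separates from the scatter in this set. Nothing available gives a reason for these numbers.

Still open, on these data alone, is whether a morpholin-4-yl group or a primary amine at this place would produce a step beyond the scatter. Also open, as far as these compounds go, is whether a methoxy or trifluoromethyl group on the aromatic carbon that carries fluoro in compound 4 would do so.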